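The compounds below may be only part of what the source reports. "The series", "measured", "known", "first", "only" and "open" are said of these compounds alone.

Measured so far:
compound 1 `COc1ccc2cc(C(C)c3nnc4n3N=C(c3ccc(F)cc3)CS4)ccc2c1` — 15800 nM
compound 2 `COc1ccc2cc(C(C)c3n[nH]c(=S)n3N)ccc2c1` — 22300 nM
compound 3 `CC(c1ccc(-c2ccccc2)c(F)c1)c1nnc2n1N=C(c1ccc([N+](=O)[O-])cc1)CS2` — 7800 nM

All three numbers come from a functional assay on MCF7 cells (Homo sapiens) for inhibition, read by sulforhodamine B assay, with a stated time of 72 h; on this read-out lower numbers stand for stronger inhibition and higher numbers for weaker inhibition. Compound 1 stands second highest of the three. Its nearest neighbour is compound 2, whose number in this assay is somewhat higher but within the scatter of the method, so the two cannot be told apart. Compound 3 gives the lowest number of the set in this assay, and its gap to compound 1 lies beyond the scatter; compound 3 also differs from compound 1 in more than one place, so no single change can be read from that pair.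

The next compound, compound 4 `COc1ccc2cc(C(C)c3nnc4n3N=C(c3ccc(C)cc3)CS4)ccc2c1`, keeps the shared core of compound 1 and changes one substituent: methyl in place of fluoro on an aromatic carbon. Going by the values given here, no measured pair isolates this change, so there is nothing in the numbers to suggest a shift in either direction. The working expectation is therefore a step of a 1.1-fold lower number from compound 1 to compound 4 (0.05 log units; within the scatter), not beyond the scatter. On that basis compound 4 is estimated at 14000 nM in this assay, with a range from 6000 nM to 35000 nM.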

Compound 4, half-maximal inhibitory concentration: 11000 nM
Compound 4: the middle estimate sits 1.3-fold (0.10 log units) above what was measured, within the range that was stated.
By their numbers in this assay, from the lowest: compounds 3, 4, 1 and 2 (each within the scatter of the next, the first and the last beyond it).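

Going by these compounds alone, the first measured pair at this position, 4-fluorophenyl to 4-methylphenyl on the shared core, gives in this assay a 1.4-fold lower number from compound 1 to compound 4 (0.16 log units; within the scatter), so compound 1 and compound 4 cannot be told apart. On an aromatic carbon para to a large group, methyl in place of fluoro therefore shows no separable effect on this read-out, although this rests on a single pair and says nothing about other changes at this position. No supporting measurement bears on why the two compounds cannot be separated here.

The compounds shown do not settle whether a group of another kind at this position, such as an amine, a carboxylic acid or a longer chain, would shift the number beyond the scatter. On these data alone, it also remains open whether methyl in place of fluoro would read the same way on a compound that differs elsewhere from compound 1, since this change is seen only once.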